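Adding a Methoxy Group to a Benzothiophene Chalcone

A few compounds are considered here, and "the series" means these few. Any claim that something is new, unique, unknown or untested is made for them only; others in the source may bear on it.

Compound 1 `COc1cc2occ(-c3csc4ccccc34)c(=O)c2c(OC)c1OC` and compound 2 `COc1cc2occ(-c3csc4ccccc34)c(=O)c2cc1OC` share one core, while compound 3 `COc1cc(O)c(C(=O)/C=C/c2csc3ccccc23)cc1OC` and the not yet measured compound 4 `COc1cc(O)c(C(=O)/C=C/c2csc3ccccc23)c(OC)c1OC` share another; the difference between the two cores is not broken down here. In a functional assay on MDA-MB-231 cells (Homo sapiens) for antiproliferative activity, read by sulforhodamine B assay, with a stated time of 72 h (a lower number here means a stronger inhibitor, a higher number a weaker inhibitor), compound 1 gives 820 nM. Compound 2 reaches only a limit of the assay, > 10000 nM, which is the limit of > 10000 nM in this assay, at which 1 of the 3 values shown sits. The change from compound 2 to compound 1 is methoxy in place of hydrogen on an aromatic carbon, and it made an at least 12-fold lower number from compound 2 to compound 1 (1.08 log units; beyond the scatter). In this assay compound 3 gives 690 nM, a number close to that of compound 1. Compound 4 differs from compound 3 by methoxy in place of hydrogen on an aromatic carbon, the same kind of change, though here the new group sits ortho to a large group and meta to a hydroxy group, rather than ortho and meta to a fused ring. In this assay the expected step is a 2.3-fold lower number from compound 3 to compound 4 (0.36 log units; beyond the scatter), set beside an at least 12-fold lower number from compound 2 to compound 1 (1.08 log units; beyond the scatter) and resting on it. The step is kept smaller only because compound 3 already gives 690 nM. Compound 4 is therefore estimated at 300 nM, between 80 nM and 1500 nM.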

Compound 4, half-maximal inhibitory concentration: 6900 nM
Estimate against measurement, compound 4: 23-fold (1.36 log units) below, outside the stated range (above it).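

On the second core, methoxy in place of hydrogen on an aromatic carbon gave a 10-fold higher number from compound 3 to compound 4 (1.00 log units; beyond the scatter) in this assay, so the gain seen on the first core did not carry over. The same change therefore ran in opposite directions on the two cores, and the gap between the two steps is larger than measurement scatter can explain: the same change on two cores in this assay, an at least 12-fold lower number (1.08 log units; beyond the scatter) from compound 2 to compound 1 and a 10-fold higher number (1.00 log units; beyond the scatter) from compound 3 to compound 4, at least 120-fold (2.08 log units) apart, beyond the scatter of two such steps

This shows that, in this series, the effect of this methoxy group on one core cannot simply be transferred to the other, but with a single pair on each core it does not show why the two results differ or what the change would do on any further core.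

The compounds shown leave open whether another group on the same carbon, such as an ethoxy group, a fluorine atom or an amine, would follow the methoxy result on either core. They also leave open how the hydroxy group shared by compound 3 and compound 4 bears on the result.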